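This account rests on a few compounds, and the source may have more. Where it says the series, first, only, none or still open, it means among the compounds named here.

Measured in a functional assay on MOLT-4 cells (Homo sapiens) for antiproliferative activity; a lower number here means a stronger inhibitor, a higher number a weaker inhibitor:
- compound 1 `COc1ccc(-c2cc(N)c(C(=O)c3cc(OC)c(OC)c(OC)c3)s2)cc1OC`: 20 nM
- compound 2 `COc1cccc(-c2cc(N)c(C(=O)c3cc(OC)c(OC)c(OC)c3)s2)c1`: 17 nM

Only these two compounds have been measured so far, and their values lie within the scatter of each other, so compound 2 stands level with compound 1 and neither can be ranked above the other. The next compound to be measured is compound 3 `COc1ccc(-c2cc(N)c(C(=O)c3cc(OC)c(OC)c(OC)c3)s2)cc1`. It keeps the shared core of compound 2 and changes one group: 4-methoxyphenyl in place of 3-methoxyphenyl on an aromatic carbon. In words, 4-methoxyphenyl stands in place of 3-methoxyphenyl on an aromatic carbon, and the atom counts stay the same.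

Among the compounds with values here, only one measured step bears on this change, a 1.2-fold lower number from compound 1 to compound 2 (0.07 log units; within the scatter), with hydrogen in place of methoxy on an aromatic carbon. That step is small and stays within the scatter, but it removes a methoxy group rather than moving one, so it is only an indirect guide. Within the data shown here, no measured pair shows this exact exchange. No shift beyond the scatter is therefore expected in this assay, in either direction, though the uncertainty remains wide. The estimated change is a 1.1-fold lower number from compound 2 to compound 3 (0.05 log units; within the scatter). Compound 3 is expected at about 15 nM, within an estimated range of 4 nM to 60 nM.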

Compound 3, half-maximal inhibitory concentration: 18 nM
Compound 3: the middle estimate sits 1.2-fold (0.08 log units) below what was measured; measured number inside the range.
By their numbers in this assay, from the lowest: compounds 2, 3 and 1 (each within the scatter of the next).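

In this assay, within the data shown here, the step of a 1.1-fold higher number from compound 2 to compound 3 (0.02 log units; within the scatter) gives the first direct reading of where the single methoxy group stands on the phenyl group attached next to the ring sulfur, and this exchange of 3-methoxyphenyl for 4-methoxyphenyl stays within the scatter. Read with the earlier step of a 1.2-fold lower number from compound 1 to compound 2 (0.07 log units; within the scatter) the new step of a 1.1-fold lower number from compound 1 to compound 3 (0.05 log units; within the scatter) shows that either methoxy group of compound 1 can give way to hydrogen with the result still within the scatter, so among these three compounds neither placement stands apart and the second methoxy group shows no measurable contribution. Nothing available on these compounds accounts for why the values stay level.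

As far as these compounds go, what remains open is whether any methoxy group is needed at all, since a plain phenyl group, a hydroxyl or a fluorine at this place could behave quite differently. The compounds also leave open how much the amino group on the shared core or the trimethoxybenzoyl part contributes, for instance if a dimethylamino group or a shorter methoxybenzoyl group stood there instead.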